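Removing the isopropyl group from compound 3

This account rests on a few compounds, and the source may have more. Where it says the series, first, only, none or still open, it means among the compounds named here.

Among the three measured compounds, compound 3 `C#CCN(CCCCOc1ccc2ccc(=O)oc2c1)Cc1ccc(C(C)C)cc1` gives the highest number in an assay on isolated protein for inhibition of Amine oxidase [flavin-containing] B (Homo sapiens), read by fluorescence and Amplex Red, with stated times of 15 min and 20 min (on this read-out lower numbers stand for stronger inhibition and higher numbers for weaker inhibition), with compound 3 at 3500 nM. Compound 1 `C#CCN(CCCCOc1ccc2ccc(=O)oc2c1)Cc1ccc(OC)cc1` gives 1130 nM, and compound 2 `C#CCN(CCCCOc1ccc2ccc(=O)oc2c1)Cc1cccc(F)c1` gives 1550 nM. Compound 4 `C#CCN(CCCCOc1ccc2ccc(=O)oc2c1)Cc1ccccc1` differs from compound 3 by hydrogen in place of isopropyl on an aromatic carbon. Among the compounds with values here, two measured steps bear on this change: a 3.1-fold higher number from compound 1 to compound 3 (0.49 log units; beyond the scatter) and a 2.3-fold higher number from compound 2 to compound 3 (0.35 log units; beyond the scatter), both showing the isopropyl-bearing compound 3 with the higher number. Going the other way, from compound 3 to compound 4, a modest step toward a lower number is therefore expected, estimated as a 2.7-fold lower number from compound 3 to compound 4 (0.43 log units; beyond the scatter). Compound 4 is expected to give about 1300 nM in this assay, estimated to fall between 600 nM and 3000 nM.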

Compound 4, half-maximal inhibitory concentration: 978 nM
Estimate against measurement, compound 4: 1.3-fold (0.12 log units) above; measured number inside the range.
By their numbers in this assay, from the lowest: compounds 4, 1 and 2 (each within the scatter of the next); then compound 3.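

In this assay, the phenyl compound shows that the isopropyl group itself carries the higher number at this position: a 3.6-fold lower number from compound 3 to compound 4 (0.55 log units; beyond the scatter). The 3-fluorophenyl and 4-methoxyphenyl compounds stay within the scatter of phenyl, with a 1.6-fold lower number from compound 2 to compound 4 (0.20 log units; within the scatter) and a 1.2-fold lower number from compound 1 to compound 4 (0.06 log units; within the scatter), so only isopropyl separates from hydrogen here. Nothing given explains why isopropyl alone stands apart. From the compounds shown here alone, it remains open whether methyl or tert-butyl at this place would give a number near compound 4 or near compound 3, and how an amine or a carboxylic acid there would read.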